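The compounds below may be only part of what the source reports. "The series", "measured", "known", "first", "only" and "open" are said of these compounds alone.

Of the compounds shown here, three have so far been tested in an assay on isolated protein for inhibition of DNA topoisomerase 1 (Homo sapiens), with a stated time of 15 min; on this read-out lower numbers stand for stronger inhibition and higher numbers for weaker inhibition. Compound 1 `CN[C@@H]1CCN(c2cc3c(cc2F)c(=O)c(C(=O)O)cn3Cc2ccc(-c3ccccc3)cc2)C1` gives 34800 nM in this assay, the lowest of the two numbers measured. Compound 2 `COc1c(N2CC[C@@H](CN)C2)c(F)cc2c(=O)c(C(=O)O)cn(Cc3cc(-c4ccccc4)no3)c12` gives 178000 nM in this assay, the higher number, and the gap between compound 1 and compound 2 lies beyond the usual scatter. Compound 3 `NC[C@@H]1CCN(c2cc3c(cc2F)c(=O)c(C(=O)O)cn3Cc2nc(-c3ccncc3)no2)C1` gives > 200000 nM in this assay, which is a limit of the assay and not a number. Compound 4 `CNCCCNc1cc2c(cc1F)c(=O)c(C(=O)O)cn2Cc1ccc(-c2ccccc2)cc1` has not yet been measured. It differs from compound 1 in one place: (3-(methylamino)propyl)amino in place of 3-(methylamino)pyrrolidin-1-yl on an aromatic carbon. A chain with no ring thus replaces the five-membered non-aromatic ring. The expected step of a 2.3-fold higher number from compound 1 to compound 4 (0.36 log units; beyond the scatter) points toward weaker inhibition, beyond the scatter. Compound 4 is estimated at 80000 nM, within 25000 nM to 200000 nM.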

Compound 4, half-maximal inhibitory concentration: 63600 nM
Compound 4: middle estimate off by 1.3-fold (0.10 log units), on the high side; low and high end bracket the measured number.
By their numbers in this assay, from the lowest: compounds 1 and 4 (each within the scatter of the next); then compound 2. At a limit, above all of these: compound 3.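

On the aromatic carbon ortho to a fluoro group, (3-(methylamino)propyl)amino in place of 3-(methylamino)pyrrolidin-1-yl gives a 1.8-fold higher number from compound 1 to compound 4 (0.26 log units; within the scatter). On the core of compound 1, then, neither the five-membered non-aromatic ring nor its defined stereocentre is needed to keep the number within the scatter. Nothing measured here gives a reason for this result.

On these data alone, it remains open whether a longer chain or a dimethylamino group at the chain's end would move the number beyond the scatter. As far as these compounds go, whether either could give stronger inhibition also remains open.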